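The source may report more compounds than this note shows. Statements on the series, on what has been measured and on what is new or still open speak of the compounds shown alone.

Measured compounds and their values:

Compound 1 `O=C(CCCCCN1CCN(c2ccccc2-c2ccccc2)CC1)N1CCc2ccccc2C1` in an assay on HEK293 cells for displacement of a labelled ligand from 5-hydroxytryptamine receptor 7 (Rattus norvegicus) (on this read-out lower numbers stand for stronger inhibition and higher numbers for weaker inhibition), gives 3.81 nM.
Compound 2 `CSc1ccccc1N1CCN(CCCCCC(=O)NCc2ccccc2)CC1` in this assay gives 22 nM.
Compound 3 `O=C(CCCCCN1CCN(c2ccccc2-c2ccccc2)CC1)NCc1ccccc1` in this assay gives 0.8 nM.

Compound 3 has the lowest number of the three, so on these data it is the strongest binder of the set. The step of a 4.8-fold lower number from compound 1 to compound 3 (0.68 log units; beyond the scatter) shows that exchanging the ring-bound amide partner for a benzylamide helps, and the step of a 28-fold lower number from compound 2 to compound 3 (1.44 log units; beyond the scatter) shows that the group on the aromatic ring next to the piperazine matters even more.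

Compound 4 `COc1ccccc1N1CCN(CCCCCC(=O)NCc2ccccc2)CC1` keeps the benzylamide and the chain of compound 3 but carries a different group on that aromatic ring: methoxy in place of phenyl on an aromatic carbon. Among the measured compounds shown here, of the measured steps, only the one from compound 2 to compound 3 speaks to this position, and it moved the number by a large amount when a small group was replaced by a phenyl. The change to compound 4 goes the other way, from the phenyl back to a small group, so a clearly higher number is expected, though how close a methoxy comes to a methylsulfanyl is not known from these compounds. The expected step is a 19-fold higher number from compound 3 to compound 4 (1.27 log units; beyond the scatter). Compound 4 is therefore estimated at 15 nM, with a range from 5 nM to 50 nM.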

Compound 4, inhibition constant: 224 nM
Compound 4: middle estimate off by 15-fold (1.17 log units), on the low side; measured number above the stated range.
By their numbers in this assay, from the lowest: compound 3; then compound 1; then compound 2; then compound 4.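

In this assay, among the compounds shown here, the place on the aromatic carbon ortho to a large group proves even more sensitive than the earlier compounds suggested: with methoxy in place of phenyl, the data show a 280-fold higher number from compound 3 to compound 4 (2.45 log units; beyond the scatter) on the same benzylamide and chain. Small groups at this place are also not interchangeable, as methoxy in place of methylsulfanyl gives a 10-fold higher number from compound 2 to compound 4 (1.01 log units; beyond the scatter) and so separates two groups that the earlier compounds could not tell apart. Phenyl, methylsulfanyl and methoxy therefore form a clear order from lowest number to highest, but nothing measured here explains that order.

These three groups do not show whether the low number of compound 3 needs an aromatic ring at this place, a question that a cyclohexyl ring, a pyridyl ring or a single chlorine atom could help to address. Methoxy or methylsulfanyl on the tetrahydroisoquinoline amide of compound 1 would also be needed to tell whether the same order holds beyond the benzylamide.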